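Aminopyrrolidine to aminopiperidine: solubility working notes

The source may report more compounds than this note shows. Statements on the series, on what has been measured and on what is new or still open speak of the compounds shown alone.

Measured so far in a physicochemical assay for solubility, read by LC-MS, in phosphate buffer, with a stated time of 24 h, at pH 7.4 (a lower number here means a less soluble compound, a higher number a more soluble compound), as read-out of solubility:
compound 1 `CC(=O)Nc1cc(Nc2cc(NC3CC3)n3ncc(C#N)c3n2)ccc1N1CC[C@H](N(C)C)C1` gives > 800000 nM as a limit, not a number
compound 2 `CC(=O)Nc1cc(Nc2cc(NC3CC3)n3ncc(C#N)c3n2)ccc1N1CC[C@@H](N)C1` gives 812000 nM as a number

Going by the values given here, compound 2 holds the only true number so far at 812000 nM in these notes. The other value is a limit for compound 1 (the limit of > 800000 nM in this assay, at which 1 of the 2 values shown sits) and not a number.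

Next comes compound 3 `CC(=O)Nc1cc(Nc2cc(NC3CC3)n3ncc(C#N)c3n2)ccc1N1CCC[C@@H](N)C1` with 3-aminopiperidin-1-yl in place of 3-aminopyrrolidin-1-yl on an aromatic carbon so that the ring goes from five-membered to six-membered. Among the compounds with values here, the only measured step (a step that the limit leaves unreadable from compound 1 to compound 2) changes the group at the same aromatic carbon but has no readable size to carry over, and no measured step changes the ring size. No change beyond the scatter is therefore expected in this assay and no direction can be named. The expected step is a 1.0-fold lower number from compound 2 to compound 3 (0.02 log units; within the scatter) and it is estimated to stay within the scatter. For compound 3 the estimate is 780000 nM with an expected range from 350000 nM to 1000000 nM in this read-out.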

Compound 3, solubility: > 1000000 nM
Compound 3 ended at the assay's limit; the forecaster's own chance of this, stated with the estimate: 45%; at least 1.2-fold (0.10 log units) between middle value and limit.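

In this assay, at the aromatic carbon ortho to an acetamido group, 3-aminopiperidin-1-yl in place of 3-aminopyrrolidin-1-yl gives an at least 1.2-fold higher number from compound 2 to compound 3 (0.09 log units; that floor lies within the scatter), the only step shown here with a readable floor and the only one that changes the ring from five-membered to six-membered. The true size of this step cannot be told, since the value for compound 3 is a limit and not a number: the limit of > 1000000 nM in this assay, at which 1 of the 3 values shown sits.

The steps from compound 1 to compound 2 and from compound 1 to compound 3 cannot be read.

Still open, on these data alone, is how far compound 1 and compound 3 lie past their limits, so no order among the three compounds can be stated from these values. Also open, as far as these compounds go, is what this assay would read for a six-membered ring carrying dimethylamino in place of the amine, or for a carboxylic acid on the same ring at this aromatic carbon.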